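Swapping cyano for tert-butyl on the benzyl ring

The source may hold more compounds than are shown below. What is called first, only, known or untested is meant among the compounds shown, and "the series" means these compounds.

Measured so far:
- Compound 1 `CC(C)n1ncc2c(C(=O)NCc3cn(Cc4ccccc4)nn3)cccc21`: 14300 nM
- Compound 2 `CC(C)n1ncc2c(C(=O)NCc3cn(Cc4ccc(C#N)cc4)nn3)cccc21`: 39600 nM

Among the compounds with values here, in a functional assay on MGC-803 cells (Homo sapiens) for inhibition, read by MTT assay, with a stated time of 72 h (on this read-out higher numbers stand for weaker inhibition and lower numbers for stronger inhibition), compound 2 gives the higher of the two numbers recorded, and its only neighbour is compound 1 at 14300 nM; the gap, a 2.8-fold higher number from compound 1 to compound 2 (0.44 log units; beyond the scatter), comes from placing cyano where compound 1 carries hydrogen on an aromatic carbon.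

Compound 3 `CC(C)n1ncc2c(C(=O)NCc3cn(Cc4ccc(C(C)(C)C)cc4)nn3)cccc21` differs from compound 2 by tert-butyl in place of cyano on an aromatic carbon, that is, the change reads 4-cyanophenyl to 4-(tert-butyl)phenyl. Within the data shown here, no measured pair shows a cyano-to-tert-butyl swap, so the only step that bears on it is a 2.8-fold higher number from compound 1 to compound 2 (0.44 log units; beyond the scatter), which shows that adding cyano to the bare ring cost potency. Going by these compounds, removing the cyano could therefore plausibly recover that loss, while what tert-butyl adds on its own is unknown here. The expected step is a 2.6-fold lower number from compound 2 to compound 3 (0.42 log units; beyond the scatter), a lower number. Compound 3 is estimated at 15000 nM in this assay, with a range from 5000 nM to 45000 nM.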

Compound 3, half-maximal inhibitory concentration: > 40000 nM
Compound 3 ended at the assay's limit (the forecaster's own chance of this, stated with the estimate: 10%); middle value at least 2.6-fold (0.42 log units) from the limit.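

In this assay compound 3 gives > 40000 nM, which is a limit of the assay and not a number. Within the data shown here, the earlier compounds showed only that cyano on this ring carbon goes with weaker inhibition than hydrogen, and tert-butyl now does the same, with an at least 2.7-fold higher number from compound 1 to compound 3 (0.44 log units; beyond the scatter). Among the three compounds, then, the loss is not confined to the nitrile: both groups, one containing nitrogen and one of carbon only, do worse than hydrogen, while the remaining step is a number no lower from compound 2 to compound 3 (the limit leaves the size open) and its size cannot be read, so neither group can be ranked above the other.

Going by these compounds, what remains open is whether any group at this place does better than hydrogen. A small fluorine or methyl, or an amine or a carboxylic acid, could each answer that differently.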